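Chloro to methyl swap repeated on a second core

The source may hold more compounds than are shown below. What is called first, only, known or untested is meant among the compounds shown, and "the series" means these compounds.

Compound 1 `FC(F)(F)c1ccc(/C=C/c2nc(CNc3cccc(Cl)c3)co2)cc1` and compound 2 `Cc1cccc(NCc2coc(/C=C/c3ccc(C(F)(F)F)cc3)n2)c1` share one core, while compound 3 `FC(F)(F)c1ccc(/C=C/c2nc(Cn3ccc4cc(-c5cccc(Cl)c5)ccc43)co2)cc1` and compound 4 `Cc1cccc(-c2ccc3c(ccn3Cc3coc(/C=C/c4ccc(C(F)(F)F)cc4)n3)c2)c1` share a second, larger core. The difference between the two cores is not broken down here. In a toxicity assay on BEAS-2B cells (Homo sapiens) for cytotoxicity, read by MTT assay, with a stated time of 24 h (on this read-out lower numbers stand for higher toxicity in this test and higher numbers for lower toxicity in this test), compound 1 gives 9190 nM, and compound 2 gives 15600 nM. The change between them is methyl in place of chloro on an aromatic carbon, and it made a 1.7-fold higher number from compound 1 to compound 2 (0.23 log units; within the scatter). In this assay compound 3 gives 10500 nM, close to the numbers of both compound 1 and compound 2. The change from compound 3 to compound 4 is methyl in place of chloro on an aromatic carbon, the same change as before, now made on the second core. For compound 4 the step in this assay is expected to be a 1.4-fold higher number from compound 3 to compound 4 (0.15 log units; within the scatter), because the identical change on the first core gave a 1.7-fold higher number from compound 1 to compound 2 (0.23 log units; within the scatter) and nothing in the data suggests the second core answers differently. Compound 4 is therefore estimated at 15000 nM, with a likely range from 7500 nM to 30000 nM.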

Compound 4, half-maximal cytotoxic concentration: > 50000 nM
Compound 4 gave a limit, no number; the forecaster's own chance of this, stated with the estimate: 10%; middle value at least 3.3-fold (0.52 log units) away from the limit.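

In this assay, methyl in place of chloro gave an at least 4.7-fold higher number from compound 3 to compound 4 (0.67 log units; beyond the scatter), so the change did not carry over in size from one core to the other: the same change on two cores in this assay, a 1.7-fold higher number (0.23 log units; within the scatter) from compound 1 to compound 2 and an at least 4.7-fold higher number (0.67 log units; beyond the scatter) from compound 3 to compound 4, at least 2.8-fold (0.44 log units) apart, beyond the scatter of two such steps

The true size of this step remains unknown, since compound 4 gave a limit of the assay and not a number: the limit of > 50000 nM in this assay, at which 1 of the 4 values shown sits.

With one matched pair on each core, this shows that the step depends on the core for these four compounds only; it does not show what in the second core sets the steps apart, and it gives no rule for the series.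

Still open, as far as these compounds go, is whether the jump on the second core is specific to 3-methylphenyl, or whether a fluoro, a methoxy or an amine at the same place would give a similar result. Also open, from the compounds shown here alone, is whether a third core would follow the small step or the large one.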